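This account rests on a few compounds, and the source may have more. Where it says the series, first, only, none or still open, it means among the compounds named here.

Three compounds of the series have been run in an ADME assay on HCT-116 cells (Homo sapiens) for cytotoxicity, read by MTT assay, with a stated time of 72 h; on this read-out lower numbers stand for stronger inhibition and higher numbers for weaker inhibition. Compound 1 `Cc1ccc(N2C(=O)C/C(=C\c3cccc(C(=O)Nc4cccc(F)c4)c3)C2=O)cc1` gives > 100000 nM, which is a limit of the assay rather than a number. Compound 2 `O=C(Nc1ccc(OC(F)F)cc1)c1cccc(/C=C2\CC(=O)N(c3ccccc3)C2=O)c1` likewise reaches only > 100000 nM, again a limit. Compound 3 `CCCCCN1C(=O)C/C(=C\c2cccc(C(=O)NCCCC)c2)C1=O` sits at > 100000 nM, also a limit. Every value recorded so far thus rests at the same boundary: the limit of > 100000 nM in this assay, at which 3 of the 3 values shown sit. Among the compounds with values here, no step between two measured compounds can be drawn from this, and compound 2 cannot be separated from the other two on the numbers; it stands with them at the limit.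

Compound 4 `CCOc1ccc(NC(=O)c2cccc(/C=C3\CC(=O)N(c4ccccc4)C3=O)c2)cc1` differs from compound 2 in a single place, (ethyl in place of difluoromethyl on an oxygen on an aromatic ring). The shared core, the amide and the aromatic rings are unchanged.

Nothing measured in this assay distinguishes one compound from another, so no direction for the change can be read from the numbers. The expected step is one of no size beyond the scatter, a number no higher from compound 2 to compound 4 (the limit leaves the size open), with a real chance that the assay once more reports only a limit. Compound 4 is therefore estimated at 100000 nM in this assay, within a range from 30000 nM to 300000 nM.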

Compound 4, half-maximal inhibitory concentration: 84800 nM
The estimate for compound 4 lay 1.2-fold (0.07 log units) above the measured number; the range from low to high includes it.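

In this assay, within the data shown here, compound 4 gives 84800 nM, the first reading that is a number and not a limit. Ethyl in place of difluoromethyl on an oxygen on an aromatic ring gives an at least 1.1-fold lower number from compound 2 to compound 4 (0.07 log units; that floor lies within the scatter), so this place can carry a change that brings the reading inside the range of the assay, while the true size of the step stays unknown, as one end of it is a limit and the step is only a floor. Compound 4 is still a single number in a series otherwise held at the upper boundary of the assay: the limit of > 100000 nM in this assay, at which 3 of the 4 values shown sit.

A longer chain such as propyl on the same oxygen, or an amine or a carboxylic acid in place of the ethoxy group, would show whether the number in this assay can move further from this place, and the compounds shown do not settle that. Also open, from the compounds shown here alone, is whether ethoxy acts the same way with other groups elsewhere on the shared core, since this pair is the only one that differs in one place.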